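This account rests on a few compounds, and the source may have more. Where it says the series, first, only, none or still open, it means among the compounds named here.

Three compounds built on one shared core were tested in an ADME assay on L02 cells (Homo sapiens) for cytotoxicity, read by MTT assay, with a stated time of 48 h; a lower number here means a stronger inhibitor, a higher number a weaker inhibitor. Compound 1 `Cc1ccc(Cn2cc(COc3ccc4c(=O)ccoc4c3)nn2)cc1` gives only a limit of the measurement, > 300000 nM, not a number. Compound 2 `O=c1ccoc2cc(OCc3cn(Cc4cccc(F)c4)nn3)ccc12` likewise reaches only a limit, > 300000 nM. Compound 3 `O=c1ccoc2cc(OCc3cn(Cc4cccc(Cl)c4)nn3)ccc12` also stops at a limit, > 300000 nM, so it stands level with the others and none of the three can be ranked, since all share (the limit of > 300000 nM in this assay, at which 3 of the 3 values shown sit). Accordingly the step that the two limits leave unreadable from compound 1 to compound 2, the step that the two limits leave unreadable from compound 1 to compound 3 and the step that the two limits leave unreadable from compound 2 to compound 3 are all of unreadable size. Compound 4 `N#Cc1ccc(Cn2cc(COc3ccc4c(=O)ccoc4c3)nn2)cc1` differs from compound 3 by 4-cyanophenyl in place of 3-chlorophenyl on a saturated chain carbon bound to an aromatic nitrogen. Among the compounds with values here, no readable step bears on this change; the three limits are the only guide, so no movement beyond the scatter is expected. Compound 4 is therefore estimated to stay at the limit, with an expected value of 400000 nM ranging from 200000 nM to 1000000 nM. This corresponds to an expected step that the limit leaves unreadable from compound 3 to compound 4.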

Compound 4, half-maximal inhibitory concentration: > 300000 nM
Compound 4: no number, only a limit (the forecaster's own chance of this, stated with the estimate: 85%); the middle value lies beyond the limit too.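

Compound 4 stops at a limit, as compound 1, compound 2 and compound 3 do, so none of the steps between these compounds can be read: the limit of > 300000 nM in this assay, at which 4 of the 4 values shown sit. As far as these compounds go, whether any change to the group on the shared core moves the read-out at all stays open.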